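Compound 4 Follows Compound 3 to the Limit

This account rests on a few compounds, and the source may have more. Where it says the series, first, only, none or still open, it means among the compounds named here.

In an ADME assay on MRC5 cells (Homo sapiens) for inhibition, with a stated time of 72 h (on this read-out lower numbers stand for an effect already at smaller amounts and higher numbers for an effect only at larger amounts of compound), compound 3 `COCCNC(=O)c1n[nH]cc1NC(=O)c1c(OC)cccc1OC` reaches only a limit, > 50000 nM. Compound 1 `COc1cccc(OC)c1C(=O)Nc1c[nH]nc1C(=O)Nc1ccncc1` likewise gives only a limit in this assay, > 50000 nM. Compound 2 `COc1cccc(OC)c1C(=O)Nc1c[nH]nc1C(=O)N[C@H]1CC[C@H](O)CC1` gives 34000 nM in this assay. Two of the three values therefore sit at the ceiling (the limit of > 50000 nM in this assay, at which 2 of the 3 values shown sit). Compound 4 `COc1cccc(OC)c1C(=O)Nc1c[nH]nc1C(=O)NN1CCOCC1` differs from compound 3 by morpholin-4-yl in place of 2-methoxyethyl on an amide-type nitrogen. The measured steps ending at compound 3 are a step that the two limits leave unreadable from compound 1 to compound 3 and an at least 1.4-fold higher number from compound 2 to compound 3 (0.16 log units; that floor lies within the scatter); both are bounded by the limit and neither is readable beyond the scatter. Within the data shown here, no measured step bears on the entering morpholin-4-yl itself, so no change beyond the scatter is expected in this assay. Compound 4 is therefore expected to remain at the limit, estimated at 50000 nM, between 25000 nM and 100000 nM, which means a step of a number no higher from compound 3 to compound 4 (the limit leaves the size open).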

Compound 4, half-maximal effective concentration: > 50000 nM
Compound 4 ended at the assay's limit; the forecaster's own chance of this, stated with the estimate: 70%; the middle value lies on the limit itself.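

A saturated ring joined through its own nitrogen, morpholin-4-yl, now also sits at the ceiling in this assay, alongside pyridin-4-yl and 2-methoxyethyl: the limit of > 50000 nM in this assay, at which 3 of the 4 values shown sit. Among these compounds, the exchange of 4-hydroxycyclohexyl for morpholin-4-yl gives an at least 1.4-fold higher number from compound 2 to compound 4 (0.16 log units; that floor lies within the scatter), so the only readable step to compound 4 does not clear the scatter. The steps to compound 4 from compound 1 and compound 3 cannot be read, since both ends are limits.

Going by these compounds, whether an aminoethyl chain or a carboxylic acid on this amide-type nitrogen would give a number clear of the limit remains open. So does how far past the limit compound 1, compound 3 and compound 4 lie.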